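The compounds below may be only part of what the source reports. "The series", "measured", "known", "first", "only" and "open" are said of these compounds alone.

Working notes on the series, read in an ADME assay on MT4 cells (Homo sapiens) for cytotoxicity, with a stated time of 5 days; on this read-out lower numbers stand for higher toxicity in this test and higher numbers for lower toxicity in this test. For the measured compounds named here, compound 1 `CC(C)(C)C#Cc1cc(N(C(=O)[C@H]2CC[C@H](C)CC2)[C@H]2CC[C@H](Oc3ccc4nccn4n3)CC2)c(C(=O)O)s1` gives 133 nM, the lowest of three numbers so far. Compound 2 `CC(C)(C)C#Cc1cc(N(C(=O)[C@H]2CC[C@H](C)CC2)[C@H]2CC[C@H](OC3CCOCC3)CC2)c(C(=O)O)s1` gives 1990 nM and compound 3 `C[C@@H]1CC[C@@H](C(=O)N(c2cc(C#CC(C)(C)C)sc2C(=O)O)[C@H]2CC[C@H](OC3CCOC3)CC2)[C@@H](O)C1` gives 11600 nM. Compound 4 `CC(C)(C)C#Cc1cc(N(C(=O)[C@H]2CC[C@H](C)CC2)[C@H]2CC[C@H](Oc3ccncn3)CC2)c(C(=O)O)s1` is not yet measured. Its change from compound 1 is a group of 6 heavy atoms (4 carbon, 2 nitrogen; one six-membered aromatic ring with 2 hetero atoms) in place of a group of 9 heavy atoms (6 carbon, 3 nitrogen; one five-membered aromatic ring with 2 hetero atoms, one six-membered aromatic ring with 2 hetero atoms), on an oxygen on a saturated carbon, and the entering group is pyrimidin-4-yl. Going by the values given here, one measured step bears on this, at the same place: a 15-fold higher number from compound 1 to compound 2 (1.18 log units; beyond the scatter), a large rise to a non-aromatic ring, whereas pyrimidin-4-yl is aromatic. Compound 3 offers no comparable single change. Only part of that rise is therefore expected in this assay. The expected step is a 5.3-fold higher number from compound 1 to compound 4 (0.72 log units; beyond the scatter), upward and smaller than the measured one. Compound 4 is estimated at 700 nM, with an expected range of 200 nM to 2500 nM.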

Compound 4, half-maximal cytotoxic concentration: 599 nM
For compound 4 the middle estimate is 1.2-fold (0.07 log units) above the measured one; low and high end bracket the measured number.
By their numbers in this assay, from the lowest: compound 1; then compound 4; then compound 2; then compound 3.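

In this assay, keeping an aromatic group on this oxygen while dropping the fused bicyclic group still gives a 4.5-fold higher number from compound 1 to compound 4 (0.65 log units; beyond the scatter), so the rise seen earlier does not require a non-aromatic ring. Pyrimidin-4-yl in place of oxan-4-yl gives a 3.3-fold lower number from compound 2 to compound 4 (0.52 log units; beyond the scatter), placing compound 4 between the other two groups at this position. Open, from the compounds shown here alone, is whether an amine on the pyrimidin-4-yl group, or an open alkyl chain on this oxygen in place of any ring, would shift the number further. Nothing at hand bears on the reason for these steps.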